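This account rests on a few compounds, and the source may have more. Where it says the series, first, only, none or still open, it means among the compounds named here.

Measured in an assay for inhibition of Polyunsaturated fatty acid 5-lipoxygenase (Homo sapiens), read by spectrophotometry, tested at 10 uM, in the presence of a further agent that is not named here; a lower number here means less inhibition, a higher number more inhibition at the concentration tested (going by the name of the read-out):
compound 1, `Cc1nc(NC(=O)c2ccccc2)sc1C(=O)/C=C/c1ccccc1`, gives 73.5%
compound 2, `Cc1nc(NC(=O)c2ccccc2)sc1C(=O)/C=C/c1ccc(F)cc1`, gives 98%

Compound 2 stands highest of the two numbers; its nearest neighbour, compound 1, lies a step below it that is beyond the scatter, a number 24.5 percentage points higher from compound 1 to compound 2 (beyond the scatter). Compound 3, `Cc1nc(NC(=O)c2ccccc2)sc1C(=O)/C=C/c1ccc(Cl)cc1`, has not yet been measured. It differs from compound 2 in one place: chloro in place of fluoro on an aromatic carbon. Among the compounds with values here, the only measured step that touches this position is a number 24.5 percentage points higher from compound 1 to compound 2 (beyond the scatter), a modest rise when fluoro entered in place of hydrogen. Within the data shown here, no measured step exchanges fluoro for chloro, so the size of that change is not known from these data. Compound 2 with 98% already sits close to the top of what a percentage can reach, leaving little room for a further rise. For compound 3 the expected step is a number 5 percentage points lower from compound 2 to compound 3 (within the scatter), within or near the scatter, most likely a slight easing rather than a gain. Compound 3 is therefore estimated to give 93% in this assay, with a range from 78% to 100%.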

Compound 3, a percentage reported as inhibition, at one concentration (the size of the read-out at that concentration, not a potency): 63.7%
Beside the measured number, compound 3's estimate is 29.3 percentage points above it, outside the stated range (below it).
By their numbers in this assay, from the lowest: compounds 3 and 1 (each within the scatter of the next); then compound 2.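

Swapping one halogen for another at this position, para to a large group, is far from a neutral exchange: in this assay the change to chloro gives (a number 34.3 percentage points lower from compound 2 to compound 3 (beyond the scatter)) even though each group counts as a single heavy atom with no hydrogen-bond donors or acceptors. Compared with the unsubstituted phenyl, chloro gives (a number 9.8 percentage points lower from compound 1 to compound 3 (within the scatter)), so the clear rise seen with fluoro does not extend to chloro, and among these three compounds that rise belongs to fluoro alone rather than to halogens as a class. Nothing available here accounts for the different results with these two halogens.

These compounds leave open how a methyl, a methoxy, a trifluoromethyl or an amine in this same place would compare with fluoro and chloro. They also leave open how far these differences in inhibition at a single concentration reflect differences in potency, which would take full concentration-response measurements on compound 1, compound 2 and compound 3.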